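This account rests on a few compounds, and the source may have more. Where it says the series, first, only, none or still open, it means among the compounds named here.

Measured compounds in a functional assay on EC9706 cells (Homo sapiens) for cytotoxicity, read by MTT assay, with a stated time of 72 h; on this read-out higher numbers stand for weaker inhibition and lower numbers for stronger inhibition:
Compound 1 `CCNC(=O)N1CCN(C(=S)SCc2cn(Cc3ccccc3F)nn2)CC1` gives 23700 nM.
Compound 2 `CC(C)NC(=O)N1CCN(C(=S)SCc2cn(Cc3ccccc3F)nn2)CC1` gives 20800 nM.
Compound 3 `CCNC(=O)N1CCN(C(=S)SCc2cn(Cc3ccc(C)cc3)nn2)CC1` gives only a limit of the assay, > 128000 nM.

Compound 4 `Cc1ccc(Cn2cc(CSC(=S)N3CCN(C(=O)NC(C)C)CC3)nn2)cc1` has not yet been run in this assay. It stands to compound 3 as compound 2 stands to compound 1: the change methyl in place of hydrogen on a saturated chain carbon bound to an amide-type nitrogen and a saturated chain carbon is the same as methyl in place of hydrogen on a saturated chain carbon bound to an amide-type nitrogen and a saturated chain carbon, and the place is described in identical words for both pairs. The two cores differ by 4-methylphenyl in place of 2-fluorophenyl on a saturated chain carbon bound to an aromatic nitrogen, and that core change produced an at least 5.4-fold higher number from compound 1 to compound 3 (0.73 log units; beyond the scatter), a step that ends at the limit (the limit of > 128000 nM in this assay, at which 1 of the 3 values shown sits). The measured instance of the methyl change produced a 1.1-fold lower number from compound 1 to compound 2 (0.06 log units; within the scatter), a step within the scatter.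

The same outcome is expected for the new pair: the estimate means a step that the limit leaves unreadable from compound 3 to compound 4, again within the scatter, resting on a 1.1-fold lower number from compound 1 to compound 2 (0.06 log units; within the scatter). Compound 4 is therefore expected near 160000 nM, within a range from 80000 nM to 400000 nM, and the assay will most likely again report only a limit rather than a number.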

Compound 4, half-maximal inhibitory concentration: > 128000 nM
Compound 4: a limit, no number (the forecaster's own chance of this, stated with the estimate: 80%); the middle value is on the limit's open side.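

In this assay compound 4 gives only a limit, > 128000 nM, and limits now make up a large share of the values: the limit of > 128000 nM in this assay, at which 2 of the 4 values shown sit.

The step for the methyl change on the 4-methylphenyl core cannot be read, and the result neither confirms nor rules out that this change carries over from the 2-fluorophenyl core, where it gave a 1.1-fold lower number from compound 1 to compound 2 (0.06 log units; within the scatter). What can be read is the other change, 4-methylphenyl in place of 2-fluorophenyl, which gives an at least 6.1-fold higher number from compound 2 to compound 4 (0.78 log units; beyond the scatter), and it points the same way on both cores, though its size on each is not fixed: the same change on two cores in this assay, an at least 5.4-fold higher number (0.73 log units; beyond the scatter) from compound 1 to compound 3 and an at least 6.1-fold higher number (0.78 log units; beyond the scatter) from compound 2 to compound 4; the limit leaves it open whether they differ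

Open, as far as these compounds go, is which part of the aryl change carries the step, for instance how a plain phenyl or a 4-fluorophenyl group would stand in this assay. Also open, from the compounds shown here alone, is how a longer chain such as butyl, in place of ethyl or isopropyl, would read on the 2-fluorophenyl core, where values are numbers rather than limits.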